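The source may report more compounds than this note shows. Statements on the series, on what has been measured and on what is new or still open speak of the compounds shown alone.

In an assay on HEK293 cells for displacement of a labelled ligand from metabotropic glutamate receptor 5 (Rattus norvegicus) (a higher number here means a weaker inhibitor, a lower number a stronger inhibitor), compound 1 `O=C(Nc1cc(-c2ccccc2)nn1-c1ccccc1)c1cccc([N+](=O)[O-])c1` gives 2220 nM, the higher of the two numbers in hand. Compound 3 `Cc1ccc(C(=O)Nc2cc(-c3ccccc3)nn2-c2ccccc2)cc1C` gives 430 nM in this assay, and the step of a 5.2-fold lower number from compound 1 to compound 3 (0.71 log units; beyond the scatter) sits on the carbonyl side of the shared core. Compound 2 `O=C(Nc1cc(-c2ccccc2)nn1-c1ccccc1)c1cc([N+](=O)[O-])cc([N+](=O)[O-])c1` gives "not determined" (no result reported) in this assay, so no number is in hand for it. Compound 4 `O=C(Nc1cc(-c2ccccc2)nn1-c1ccccc1Br)c1cccc([N+](=O)[O-])c1` differs from compound 1 by bromo in place of hydrogen on an aromatic carbon, ortho to a large group on a six-membered aromatic ring of carbon only. For the measured compounds named here, no measured step touches that ring; the single measured step concerns the amide aryl group and is modest. With nothing bearing directly on the change, the step of a 1.1-fold lower number from compound 1 to compound 4 (0.05 log units; within the scatter) is expected to stay within the scatter. Compound 4 is therefore estimated at 2000 nM, with a range of 600 nM to 7000 nM.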

Compound 4, inhibition constant: 230 nM
Estimate against measurement, compound 4: 8.7-fold (0.94 log units) above, and the stated range ends above it.
By their numbers in this assay, from the lowest: compounds 4 and 3 (each within the scatter of the next); then compound 1.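

Bromo in place of hydrogen on this aromatic carbon gives a 9.7-fold lower number from compound 1 to compound 4 (0.98 log units; beyond the scatter) in this assay. For the compounds shown here, no earlier step touches this ring, so the phenyl to 2-bromophenyl change shows that this ring, as well as the amide aryl group, affects the number, and by a step beyond the scatter. Nothing shown accounts for the size of this step.

As far as these compounds go, whether chloro, methyl or methoxy at the same place would give a similar step remains open. So does whether the 2-bromophenyl change would carry over to the 3,4-dimethylphenyl amide of compound 3.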